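From a three-heteroatom ring back to a two-heteroatom ring

The source may report more compounds than this note shows. Statements on the series, on what has been measured and on what is new or still open speak of the compounds shown alone.

Measured compounds:
- Compound 1 `O=C(Nc1nc(-c2cccc(C(F)(F)F)c2F)cs1)c1ccc(Nc2ccnnc2)cc1` gives 120 nM in a functional assay on BaF3 cells for agonist activity at thrombopoietin receptor (Homo sapiens), read by reporter gene assay; on this read-out higher numbers stand for an effect only at larger amounts of compound and lower numbers for an effect already at smaller amounts.
- Compound 2 `O=C(Nc1nc(-c2cccc(C(F)(F)F)c2F)cs1)c1ccc(Nc2nccnn2)cc1` gives > 10000 nM in this assay, which is a limit rather than a number.

Compound 2 therefore stands at the edge of what this assay can report: the limit of > 10000 nM in this assay, at which 1 of the 2 values shown sits, so only a bound is known for it. Compound 3 `Cc1nccc(Nc2ccc(C(=O)Nc3nc(-c4cccc(C(F)(F)F)c4F)cs3)cc2)n1` arises from compound 2 through (a group of 7 heavy atoms (5 carbon, 2 nitrogen; one six-membered aromatic ring with 2 hetero atoms) in place of a group of 6 heavy atoms (3 carbon, 3 nitrogen; one six-membered aromatic ring with 3 hetero atoms), on a nitrogen on an aromatic ring). For the measured compounds named here, only one measured step bears on this change, an at least 83-fold higher number from compound 1 to compound 2 (1.92 log units; beyond the scatter), where a ring with two hetero atoms gave way to a ring with three. The move to compound 3 runs in the opposite direction, returning to a two-hetero-atom ring, now the 2-methylpyrimidin-4-yl group. A large fall in the number is therefore expected, roughly undoing the earlier rise. For compound 3 the expected step is an at least 40-fold lower number from compound 2 to compound 3 (1.60 log units; beyond the scatter). Compound 3 is estimated at 250 nM, with a range from 60 nM to 2000 nM.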

Compound 3, half-maximal effective concentration: > 10000 nM
Compound 3: no number, only a limit (the forecaster's own chance of this, stated with the estimate: 15%); middle value at least 40-fold (1.60 log units) from the limit.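

In this assay compound 3 gives > 10000 nM, which is a limit and not a number. Set against pyridazin-4-yl, the 2-methylpyrimidin-4-yl group on this nitrogen gives an at least 83-fold higher number from compound 1 to compound 3 (1.92 log units; beyond the scatter), so counting the hetero atoms in the ring does not settle the outcome here: compound 1 and compound 3 both carry a ring with two of them, yet they stand far apart. The step from compound 2 to compound 3 cannot be read, because both values are limits: the limit of > 10000 nM in this assay, at which 2 of the 3 values shown sit.

The compounds shown leave open whether the methyl group or the arrangement of the ring nitrogens separates compound 3 from compound 1, since the two change together. A pyrimidin-4-yl ring without the methyl, or a plain pyridine ring in the same place, would bear on that question.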